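Trifluoromethyl for cyano on a thienylmethyl amide series

The source may hold more compounds than are shown below. What is called first, only, known or untested is meant among the compounds shown, and "the series" means these compounds.

Compound 1 `CCN(Cc1cccs1)C(=O)COc1ccc(C(=O)O)cc1`: "not active" (no number reported)
Compound 2 `CCN(Cc1cccs1)C(=O)COc1ccc(C#N)cc1`: 1990 nM

Among the measured compounds shown here, in an assay on HEK293 cells for agonist activity at transient receptor potential cation channel subfamily M member 8 (Homo sapiens), read by fluorescence and calcium flux, with a stated time of 15 min (on this read-out higher numbers stand for an effect only at larger amounts of compound and lower numbers for an effect already at smaller amounts), compound 2 gives 1990 nM and is the only compound of the pair with a number; compound 1 gives "not active" (no number reported). Compound 3 `CCN(Cc1cccs1)C(=O)COc1ccc(C(F)(F)F)cc1` differs from compound 2 by trifluoromethyl in place of cyano on an aromatic carbon. Nothing measured here shows how that change acts, so compound 3 is expected to stay close to compound 2, with a step from compound 2 to compound 3 of a 1.3-fold lower number from compound 2 to compound 3 (0.12 log units; within the scatter) that is not expected to go beyond the scatter. Compound 3 is estimated at 1500 nM, within a range from 500 nM to 5000 nM.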

Compound 3, half-maximal effective concentration: 236 nM
Compound 3: middle estimate off by 6.4-fold (0.80 log units), on the high side; the whole stated range lies above it.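

In this assay, the group on this aromatic carbon, para to a large group, clearly matters: trifluoromethyl in place of cyano gives an 8.4-fold lower number from compound 2 to compound 3 (0.93 log units; beyond the scatter). Among the compounds shown here, compound 1 has no number, so no step can be read from it, and this is the first measured size of a change at this place. Nothing available explains the step. On these data alone, whether a methoxy group, a chlorine atom or an amine at this place would match trifluoromethyl remains open. So does whether the same exchange would give a similar step on a core other than that of compound 2.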